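Swapping bromo for fluoro in a sulfonylurea series

The compounds below may be only part of what the source reports. "The series", "measured", "known", "first", "only" and "open" are said of these compounds alone.

Compound 1, with the structure `COc1ccc(F)cc1C(C)NC(=O)NS(=O)(=O)c1ccc(Cl)cc1`, was tested in a functional assay on thoracic aorta (Rattus norvegicus, strain Wistar), with a stated time of 15 min; on this read-out lower numbers stand for an effect already at smaller amounts and higher numbers for an effect only at larger amounts of compound. In this assay compound 1 reaches only the limit of > 300000 nM, which is a boundary of the measurement rather than a number. Compound 2, with the structure `COc1ccc(Br)cc1C(C)NC(=O)NS(=O)(=O)c1ccc(C)cc1`, was tested in the same way. In this assay compound 2 likewise gives only the limit of > 300000 nM, again a boundary and not a number. Among the values shown, compound 2 therefore stands at the limit of > 300000 nM in this assay, at which 2 of the 2 values shown sit, so no compound shown so far has produced a measurable number.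

Compound 3, with the structure `COc1ccc(F)cc1C(C)NC(=O)NS(=O)(=O)c1ccc(C)cc1`, has not yet been measured. It is derived from compound 2 by a single change: fluoro in place of bromo on an aromatic carbon. Among the compounds with values here, since both measured compounds sit at the same limit, no step between measured compounds is available for comparison. The step from compound 2 to compound 3 is expected to be a step that the limit leaves unreadable from compound 2 to compound 3, that is, no change beyond the scatter. Compound 3 is therefore estimated at 400000 nM, within a range from 150000 nM to 1000000 nM, most likely again reported only as a limit.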

Compound 3, half-maximal effective concentration: > 300000 nM
Compound 3: no number, only a limit (the forecaster's own chance of this, stated with the estimate: 85%); the middle value does not contradict the limit.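

Compound 3, like compound 1 and compound 2, gives only a limit and not a number in this assay, so neither of its steps from those two compounds can be read: the limit of > 300000 nM in this assay, at which 3 of the 3 values shown sit.

The compounds shown leave open whether fluoro in place of bromo, or methyl in place of chloro, changes the effect at all.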